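This account rests on a few compounds, and the source may have more. Where it says the series, first, only, none or still open, it means among the compounds named here.

Measured so far:
- compound 1, `c1ccc(-c2ccc3nc(-c4ccccc4)cn3c2)cc1`, 4700 nM in an assay on isolated protein for inhibition of Retinaldehyde dehydrogenase 3 (Homo sapiens), with a stated time of 5 min; on this read-out lower numbers stand for stronger inhibition and higher numbers for weaker inhibition
- compound 2, `Clc1ccc(-c2cccn3cc(-c4ccccc4)nc23)cc1`, 5500 nM in this assay

Compound 2 gives the higher of the two numbers, yet its gap to compound 1 lies within the scatter, so the two cannot be told apart. Compound 3, `Fc1ccc(-c2cccn3cc(-c4ccccc4)nc23)cc1`, differs from compound 2 only by fluoro in place of chloro on an aromatic carbon. Among the measured compounds shown here, no measured pair shows the effect of this exchange, so the step is expected to stay small, with no direction beyond the scatter. For compound 3 the expected result is 5500 nM, within 2500 nM to 12000 nM, which means a step of no change at the digits printed from compound 2 to compound 3 (within the scatter).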

Compound 3, half-maximal inhibitory concentration: 6000 nM
Estimate against measurement, compound 3: 1.1-fold (0.04 log units) below; the range from low to high includes it.
By their numbers in this assay, from the lowest: compounds 1, 2 and 3 (each within the scatter of the next).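

In this assay fluoro in place of chloro, on the ring carbon para to a large group, gives a 1.1-fold higher number from compound 2 to compound 3 (0.04 log units; within the scatter) and so the two halogens cannot be told apart at this position. Among the compounds shown here, this is the first comparison in which only one place differs. Nothing measured here speaks to why the two compounds read alike. Still open, from the compounds shown here alone, is whether a group other than a halogen at this position, such as an amine or a carboxylic acid, would give a clearly different number.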